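A few compounds are considered here, and "the series" means these few. Any claim that something is new, unique, unknown or untested is made for them only; others in the source may bear on it.

Measured compounds in an assay on mitochondria for inhibition of HSP60/HSP10 (Homo sapiens); on this read-out higher numbers stand for weaker inhibition and lower numbers for stronger inhibition:
compound 1 `O=S(=O)(Nc1ccc(-c2nc3cc(NS(=O)(=O)c4ccc(Cl)s4)ccc3o2)cc1)c1ccc(Cl)c(C(F)(F)F)c1` gives 6700 nM;
compound 2 `COc1ccc(S(=O)(=O)Nc2ccc3oc(-c4ccc(NC(=O)c5cccc(C)c5[N+](=O)[O-])cc4)nc3c2)cc1` gives 72000 nM;
compound 3 `Nc1ccc(S(=O)(=O)Nc2ccc(-c3nc4cc(NS(=O)(=O)c5ccc(N)cc5)ccc4o3)cc2)cc1` gives 44000 nM.

All three share the same core and differ in the groups attached at its two ends. Compound 2 and compound 3 give numbers that lie within the usual scatter of each other, so nothing can be said about which of the two is the stronger inhibitor. Compound 1 gives a number clearly below both, a gap that goes beyond the scatter, so compound 1 is the stronger inhibitor of the three.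

Compound 4 `COc1ccc(S(=O)(=O)Nc2ccc3oc(-c4ccc(NC(=O)C5CCN(C(C)=O)CC5)cc4)nc3c2)cc1` has not yet been measured. Among the compounds with values here, it keeps the whole framework of compound 2 and changes only one group: 1-acetylpiperidin-4-yl in place of 3-methyl-2-nitrophenyl on a carbonyl carbon. The group that leaves is aromatic and carries a nitro group; the group that enters is a saturated ring carrying an acetyl group. Within the data shown here, no measured pair shows what such a swap does, so there is no step to lean on. The expected change from compound 2 to compound 4 is therefore small, a 1.2-fold lower number from compound 2 to compound 4 (0.08 log units; within the scatter), with no direction favoured beyond the scatter. On that basis compound 4 is expected to give about 60000 nM in this assay, somewhere between 15000 nM and 250000 nM.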

Compound 4, half-maximal inhibitory concentration: 24000 nM
Compound 4: middle estimate off by 2.5-fold (0.40 log units), on the high side, within the range that was stated.
By their numbers in this assay, from the lowest: compound 1; then compounds 4, 3 and 2 (each within the scatter of the next, the first and the last beyond it).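

Within the data shown here, this is the first pair that differs in one place only, and it shows that the group on the carbonyl carbon, whose other neighbour is the amide-type nitrogen, can shift the result in this assay: 1-acetylpiperidin-4-yl in place of 3-methyl-2-nitrophenyl gives a 3.0-fold lower number from compound 2 to compound 4 (0.48 log units; beyond the scatter), a modest step towards stronger inhibition. An aromatic ring carrying a nitro group is therefore not needed at this place for the inhibition seen with compound 2, as a saturated ring carrying an acetyl group gives the lower number. No measurement at hand accounts for this step.

From the compounds shown here alone, the aromatic ring, the nitro group, the methyl group and the acetyl group all change together in this single step, so it remains open which of these changes matters. Also open, going by these compounds, is what a piperidine with a free amine in place of the acetyl group, or a carboxylic acid on the ring, would give here, and whether the step would hold with a different group at the other end of the molecule.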